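A few compounds are considered here, and "the series" means these few. Any claim that something is new, unique, unknown or untested is made for them only; others in the source may bear on it.

Working notes on the series. Compound 1 `Oc1ccccc1-c1cc(-c2cccs2)cc(-c2ccccc2O)n1` carries two 2-hydroxyphenyl groups and a thiophen-2-yl group on the shared core. In a functional assay on DU-145 cells (Homo sapiens) for cytotoxicity, read by CCK-8 assay (a lower number here means a stronger inhibitor, a higher number a weaker inhibitor), compound 1 gives > 50000 nM, which is a limit of the assay rather than a number. Compound 1 sits at the limit of > 50000 nM in this assay, at which 1 of the 3 values shown sits. Compound 2 `Oc1cccc(-c2cc(-c3cccs3)cc(-c3ccccc3O)n2)c1` differs from compound 1 by 3-hydroxyphenyl in place of 2-hydroxyphenyl on an aromatic carbon. In this assay compound 2 gives 9300 nM, so that an at least 5.3-fold lower number from compound 1 to compound 2 (0.73 log units; beyond the scatter). Within the data shown here, compound 3 `Oc1cccc(-c2cc(-c3ccco3)cc(-c3ccccc3O)n2)c1` follows with a 5.2-fold lower number from compound 2 to compound 3 (0.72 log units; beyond the scatter); in this assay compound 3 gives 1790 nM, the lower of the two numbers so far. The difference between the core of compound 1 and the core of compound 3 is not broken down here.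

Compound 4 `Oc1cccc(-c2cc(-c3ccco3)cc(-c3cccc(O)c3)n2)c1` is not yet measured and differs from compound 3 by 3-hydroxyphenyl in place of 2-hydroxyphenyl on an aromatic carbon. This is the same kind of change as from compound 1 to compound 2, not the same: there the carbon stood meta to a 2-hydroxyphenyl group and meta to a thiophen-2-yl group, here it stands meta to a 3-hydroxyphenyl group and meta to a furan-2-yl group. The expected step in this assay is a 4.0-fold lower number from compound 3 to compound 4 (0.60 log units; beyond the scatter), a smaller step than the earlier one, and this expectation rests on compound 1 and compound 2, where an at least 5.3-fold lower number from compound 1 to compound 2 (0.73 log units; beyond the scatter) is only known from a limit and the remaining 2-hydroxyphenyl group in compound 3 may contribute less than the first. Compound 4 is thus estimated at 450 nM in this assay. The expected range for compound 4 runs from 150 nM to 1800 nM.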

Compound 4, half-maximal inhibitory concentration: 2150 nM
The estimate for compound 4 lay 4.8-fold (0.68 log units) below the measured number; measured number above the stated range.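

In this assay, the replacement of 2-hydroxyphenyl by 3-hydroxyphenyl gives a 1.2-fold higher number from compound 3 to compound 4 (0.08 log units; within the scatter), so the clear drop seen on the core of compound 1 does not carry over to the core of compound 3, and the two steps differ: the same change on two cores in this assay, an at least 5.3-fold lower number (0.73 log units; beyond the scatter) from compound 1 to compound 2 and a 1.2-fold higher number (0.08 log units; within the scatter) from compound 3 to compound 4, at least 6.4-fold (0.81 log units) apart, beyond the scatter of two such steps

Compound 1 gives > 50000 nM, which is a limit of the assay and not a number.

The result shows that this change cannot be transferred as a fixed increment within the series, but it does not show which feature of the core sets the outcome, since the two pairs differ both in the furan-2-yl or thiophen-2-yl group and in the 2-hydroxyphenyl or 3-hydroxyphenyl group that stays in place.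

Still open, from the compounds shown here alone, is how the same change behaves on a core carrying furan-2-yl with two 2-hydroxyphenyl groups, or on one carrying thiophen-2-yl with a 3-hydroxyphenyl group already in place, which would separate those two features. The compounds shown also leave open whether a methoxy group, an amine or a carboxylic acid in place of the hydroxy group on these phenyl rings would hold the number near that of compound 3 and compound 4.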